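The compounds below may be only part of what the source reports. "The series", "measured", "known", "first", "only" and "open" are said of these compounds alone.

Working notes on the series. Compound 1 `CC1=NC(C)=C([N+](=O)[O-])C(c2ccccn2)/C1=C(/O)OCCc1ccccc1` gives 639 nM in a functional assay (muscle tissue) with Cavia porcellus as the target; a higher number here means a weaker inhibitor, a lower number a stronger inhibitor. Compound 2 `CC1=NC(C)=C([N+](=O)[O-])C(c2cccc(C)n2)/C1=C(/O)OCCc1ccccc1` gives 9980 nM in this assay, and compound 3 `CC1=NC(C)=C([N+](=O)[O-])C(c2cccc(C(F)(F)F)n2)/C1=C(/O)OCCc1ccccc1` gives 1410 nM in this assay. Compound 3 thus holds the second highest of the three numbers: toward compound 1 the step is a 2.2-fold higher number from compound 1 to compound 3 (0.34 log units; beyond the scatter), toward compound 2 it is a 7.1-fold lower number from compound 2 to compound 3 (0.85 log units; beyond the scatter), and a 16-fold higher number from compound 1 to compound 2 (1.19 log units; beyond the scatter) closes the triangle.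

Compound 4 `CC1=NC(C)=C([N+](=O)[O-])C(c2ncccc2C(F)(F)F)/C1=C(/O)OCCc1ccccc1` differs from compound 3 in one place: 3-(trifluoromethyl)pyridin-2-yl in place of 6-(trifluoromethyl)pyridin-2-yl on a saturated ring carbon. Among the compounds with values here, none of the measured steps moves a group from one ring position to another; all three swap hydrogen, methyl and trifluoromethyl at a single aromatic carbon, and they show that changes in this part of the molecule shift this assay by modest to large amounts. The shift for compound 4 is therefore expected to fall within that span, with its direction not settled by the data. Compound 4 is expected to give 900 nM in this assay, with a range of 200 nM to 4000 nM, which amounts to an expected step of a 1.6-fold lower number from compound 3 to compound 4 (0.19 log units; within the scatter).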

Compound 4, half-maximal inhibitory concentration: > 59800 nM
Compound 4: a limit, no number; the forecaster's own chance of this, stated with the estimate: 5%; middle value at least 66-fold (1.82 log units) away from the limit.
By their numbers in this assay, from the lowest: compound 1; then compound 3; then compound 2. At a limit, above all of these: compound 4.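

In this assay compound 4 gives a limit of the assay and not a number: the limit of > 59800 nM in this assay, at which 1 of the 4 values shown sits. With the same atoms joined differently, 3-(trifluoromethyl)pyridin-2-yl in place of 6-(trifluoromethyl)pyridin-2-yl gives an at least 42-fold higher number from compound 3 to compound 4 (1.62 log units; beyond the scatter), so where the trifluoromethyl group sits on the pyridine ring matters more here than any swap of hydrogen, methyl and trifluoromethyl seen so far, the largest of which is a 16-fold higher number from compound 1 to compound 2 (1.19 log units; beyond the scatter). The remaining steps, an at least 5.9-fold higher number from compound 2 to compound 4 (0.77 log units; beyond the scatter) and an at least 93-fold higher number from compound 1 to compound 4 (1.97 log units; beyond the scatter), set compound 4 apart from all three earlier compounds as the weakest of the series.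

The limit fixes only a minimum size for these steps, not their true size. On these data alone, whether a 3-methylpyridin-2-yl group, or an amine in the same ring position, would show the same drop remains open, so the effect cannot yet be assigned to the position alone or to trifluoromethyl at that position.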